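The source may hold more compounds than are shown below. What is called first, only, known or untested is meant among the compounds shown, and "the series" means these compounds.

Of the compounds shown here, three that share one core have been read in an assay on HEK293 cells for positive allosteric modulation of metabotropic glutamate receptor 3 (Rattus norvegicus), read by thallium flux, with a stated time of 2.5 min; on this read-out higher numbers stand for larger maximal responses and lower numbers for smaller maximal responses. In this assay compound 1 `Cc1c(OCCCCOc2ccc(C(=O)O)c(Cl)c2)ccc(C(=O)CC(C)C)c1C` gives 12%, compound 2 `Cc1c(OCCCCOc2ccc(F)c(C(=O)O)c2)ccc(C(=O)CC(C)C)c1C` gives 13.8%, and compound 3 `Cc1c(OCCCCOc2ccccc2C(=O)O)ccc(C(=O)CC(C)C)c1C` gives 30.7%. Compound 3 stands highest of the three: the step of a number 16.9 percentage points higher from compound 2 to compound 3 (beyond the scatter) and the step of a number 18.7 percentage points higher from compound 1 to compound 3 (beyond the scatter) both lie beyond the scatter, whereas the step of a number 1.8 percentage points higher from compound 1 to compound 2 (within the scatter) does not, so compounds 1 and 2 cannot be ordered against each other.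

Compound 4 `COC(=O)c1ccc(OCCCCOc2ccc(C(=O)CC(C)C)c(C)c2C)cc1` has not yet been measured and differs from compound 3 in one place: 4-(methoxycarbonyl)phenyl in place of 2-carboxyphenyl on an oxygen on a saturated carbon. The 2-carboxyphenyl leaves and a 4-(methoxycarbonyl)phenyl enters, so one hydrogen-bond donor leaves and two hydrogen-bond acceptors enter on the oxygen on a saturated carbon.

Among the compounds with values here, no measured step exchanges a carboxy group for a methoxycarbonyl group, so the change is only partly covered. From the compounds shown here alone, the steps of a number 18.7 percentage points higher from compound 1 to compound 3 (beyond the scatter) and a number 16.9 percentage points higher from compound 2 to compound 3 (beyond the scatter) show that the 2-carboxyphenyl, relative to the other two carboxyphenyl groups, brought a modest gain; leaving it behind points toward a loss of similar size, while the methoxycarbonyl group itself is untested. Compound 4 is therefore expected to give 18%, somewhere between 6% and 34%. This corresponds to an expected step of a number 12.7 percentage points lower from compound 3 to compound 4 (beyond the scatter).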

Compound 4, largest response reached (reported as percent of maximum), in percent of the reference or control that the assay uses: 27.3%
Beside the measured number, compound 4's estimate is 9.3 percentage points below it; low and high end bracket the measured number.
By their numbers in this assay, from the lowest: compounds 1 and 2 (each within the scatter of the next); then compounds 4 and 3 (each within the scatter of the next).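

In this assay, the step of a number 3.4 percentage points lower from compound 3 to compound 4 (within the scatter) lies within the scatter, so 4-(methoxycarbonyl)phenyl and 2-carboxyphenyl cannot be ordered on an oxygen on a saturated carbon, and compound 4 shows that a response of this size does not depend on a free carboxy group or a hydrogen-bond donor in this group. The step of a number 13.5 percentage points higher from compound 2 to compound 4 (beyond the scatter) and the step of a number 15.3 percentage points higher from compound 1 to compound 4 (beyond the scatter) both lie beyond the scatter, so 2-carboxyphenyl no longer stands alone above the two substituted carboxyphenyl groups, and a group without a carboxy function now shares its level. Nothing measured here bears on why these two different groups read alike.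

From the compounds shown here alone, it remains open how the methoxycarbonyl group compares with a carboxylic acid at the same place on the ring, as in a plain 4-carboxyphenyl or, in the other direction, a 2-(methoxycarbonyl)phenyl. Going by these compounds, it also remains open whether an unsubstituted phenyl, a primary amide or a longer chain than the one in the shared core would hold this level of response.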